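A few compounds are considered here, and "the series" means these few. Any claim that something is new, unique, unknown or untested is made for them only; others in the source may bear on it.

The measured compounds in a functional assay on UACC-257 cells (Homo sapiens) for cytotoxicity, read by sulforhodamine B assay, with a stated time of 48 h; on this read-out lower numbers stand for higher toxicity in this test and higher numbers for lower toxicity in this test:

compound 1 `ClCc1ccc(Cn2cnc3c(Cl)ncnc32)cc1` gives 97700 nM.
compound 2 `Nc1nc(Cl)c2ncn(Cc3ccccc3CCl)c2n1` gives only the assay limit > 100000 nM.
compound 3 `ClCc1ccccc1Cn1cnc2ncnc(Cl)c21` gives 61700 nM.

Compound 2 stands apart from the other two in that no number is known for it, only a limit. It sits at the limit of > 100000 nM in this assay, at which 1 of the 3 values shown sits, so how far its true toxicity lies beyond that edge cannot be read from the data.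

The piece follows the step from compound 2 to compound 4 `ClCc1ccccc1Cn1cnc2c(Cl)nc(Cl)nc21`, which has not yet been measured in this assay. The change is chloro in place of amino on an aromatic carbon. The place is on an aromatic carbon of a six-membered aromatic ring with two nitrogen atoms, part of a fused system of two rings, between two ring nitrogen atoms.

Since compound 2 is known only as a limit, the size of this step cannot be set against any measured step, and nothing here ties the amino or chloro group to a direction. Compound 4 is expected near the two numbered compounds, so the step of an at least 1.3-fold lower number from compound 2 to compound 4 (0.12 log units; that floor lies within the scatter) is an estimate only. Compound 4 is expected at 75000 nM, between 30000 nM and 180000 nM.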

Compound 4, concentration lethal to 50% of the cells: 8510 nM
Compound 4: middle estimate off by 8.8-fold (0.95 log units), on the high side; the whole stated range lies above it.
By their numbers in this assay, from the lowest: compound 4; then compounds 3 and 1 (each within the scatter of the next). At a limit, above all of these: compound 2.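

In this assay, chloro in place of amino on this aromatic carbon gives an at least 11-fold lower number from compound 2 to compound 4 (1.07 log units; beyond the scatter). Going by these compounds alone, the earlier compounds offered no step at all, so this is the first sign that a change of one heavy atom at this place, between two ring nitrogen atoms, can move the number well beyond the scatter, here towards higher toxicity in this test. The size of the step is only a floor, since compound 2 is known as a limit and not as a number: the limit of > 100000 nM in this assay, at which 1 of the 4 values shown sits.

This single pair cannot tell what about the chloro or amino group lies behind the step, or how far the true value of compound 2 lies from its limit. Going by these compounds, how a methyl group, a methoxy group or a dimethylamino group on the same carbon would compare with amino and chloro also stays open.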